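The compounds below may be only part of what the source reports. "The series", "measured", "known", "first", "only" and "open" are said of these compounds alone.

Working notes on the diaryl urea series in a functional assay on NCI-H1581 cells (Homo sapiens) for inhibition, read by MTT assay, with a stated time of 48 h, tested at 10 uM; on this read-out lower numbers stand for less inhibition and higher numbers for more inhibition at the one concentration tested (going by the name of the read-out). Two members have been measured. Compound 1 `COc1cc(NC(=O)Nc2cc(Nc3ccc(Br)cc3OC)ncn2)cc(OC)c1` gives 20.1% in this assay. Compound 2 `COc1cc(NC(=O)Nc2cc(Nc3ccc(OC)c(C)c3)ncn2)cc(OC)c1` gives 19.7% in this assay. The one step that connects them, a number 0.4 percentage points lower from compound 1 to compound 2 (within the scatter), exchanges the whole aryl on the nitrogen of the shared core, and its size is within the scatter, so compound 2 stands level with compound 1 on the numbers shown and neither number can be called the higher or the lower.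

Compound 3 `COc1cc(NC(=O)Nc2cc(Nc3ccc(OC)c(I)c3)ncn2)cc(OC)c1` is the next member. It differs from compound 2 as iodo in place of methyl on an aromatic carbon: iodo in place of methyl, on an aromatic carbon of a six-membered aromatic ring of carbon only, ortho to a methoxy group and meta to a large group. Going by the values given here, no measured step in this assay isolates this change; the only step available swaps the entire aryl and was itself within the scatter. On that basis the step from compound 2 to compound 3 is expected to be a number 2.3 percentage points higher from compound 2 to compound 3 (within the scatter), that is, no movement beyond the scatter in either direction. Compound 3 is therefore estimated at 22% in this assay, with a range from 8% to 40%.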

Compound 3, a percentage reported as inhibition, at one concentration (the size of the read-out at that concentration, not a potency): 43%
The estimate for compound 3 lay 21 percentage points below the measured number, outside the stated range (above it).
By their numbers in this assay, from the lowest: compounds 2 and 1 (each within the scatter of the next); then compound 3.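

In this assay, a number 23.3 percentage points higher from compound 2 to compound 3 (beyond the scatter) follows from iodo in place of methyl on an aromatic carbon, ortho to a methoxy group and meta to a large group. This position therefore responds to a single-atom exchange, with one heavy atom leaving, one entering and no count of hydrogen-bond donors or acceptors changing, whereas the earlier exchange of the whole aryl stayed within the scatter. The 3-iodo-4-methoxyphenyl group also stands apart from 4-bromo-2-methoxyphenyl, with a number 22.9 percentage points higher from compound 1 to compound 3 (beyond the scatter), although that comparison changes the aryl as a whole and cannot be assigned to one atom, and nothing available bears on the reason for either step.

The compounds shown leave open whether the rise is particular to iodo or would also appear with chloro, bromo or a nitrile on that same aromatic carbon. They also leave open whether it would persist with a hydroxyl or an ethoxy group in place of the neighbouring methoxy group.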